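This account rests on a few compounds, and the source may have more. Where it says the series, first, only, none or still open, it means among the compounds named here.

In an ADME assay on Huh-7 cells (Homo sapiens) for cytotoxicity, with a stated time of 72 h (a lower number here means that less compound is tolerated, a higher number that more compound is tolerated), two compounds are measured so far:

Compound 1 `CC(C)CCn1nc(-c2ccccc2)c(O)c(C2=NS(=O)(=O)c3cc(NS(C)(=O)=O)ccc3N2)c1=O`: > 1000 nM
Compound 2 `CC(C)CCn1nc(C2CCCCC2)c(O)c(C2=NS(=O)(=O)c3cc(NS(C)(=O)=O)ccc3N2)c1=O`: > 1000 nM

Both entries are limits of the assay, not numbers. Compound 2 sits at the limit of > 1000 nM in this assay, at which 2 of the 2 values shown sit. For the measured compounds named here, the one measured change, cyclohexyl in place of phenyl on an aromatic carbon, is a step that the two limits leave unreadable from compound 1 to compound 2, so no measured step has a known size.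

Compound 3 `CC(C)CCn1nc(CC2CCC2)c(O)c(C2=NS(=O)(=O)c3cc(NS(C)(=O)=O)ccc3N2)c1=O` carries cyclobutylmethyl in place of cyclohexyl on that aromatic carbon: cyclobutylmethyl in place of cyclohexyl on an aromatic carbon. With no readable step to guide the expectation, no change beyond the scatter is expected in this assay, and no direction can be predicted. The expected step is a step that the limit leaves unreadable from compound 2 to compound 3. The estimate for compound 3 is 1500 nM, with an expected range of 800 nM to 8000 nM. A further limit, rather than a number, is the most likely report.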

Compound 3, half-maximal cytotoxic concentration: > 33000 nM
Compound 3: only a limit was reported; the forecaster's own chance of this, stated with the estimate: 85%; middle value at least 22-fold (1.34 log units) away from the limit.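

In this assay compound 3 gives > 33000 nM, which is a limit and not a number. For the compounds shown here, compound 1 and compound 2 are also reported as limits, and no step among the three can be read. Still open, going by these compounds, is each compound's actual cytotoxic concentration, and whether swapping the group on that aromatic carbon changes it.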